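Notes on compound 4 against compounds 1 to 3

A few compounds are considered here, and "the series" means these few. Any claim that something is new, unique, unknown or untested is made for them only; others in the source may bear on it.

Three measured compounds share one core and differ only in the group on the ring nitrogen that also carries a saturated chain carbon. Compound 1 `CN(C(=O)c1ccccc1)c1ccc2[nH]c(-c3n[nH]c4ccccc34)cc2n1` gives 4850 nM in a functional assay on HL-60 cells (Homo sapiens) for antiproliferative activity, read by MTT assay, with a stated time of 72 h; on this read-out lower numbers stand for stronger inhibition and higher numbers for weaker inhibition. Compound 2 `COc1cccc(C(=O)N(C)c2ccc3[nH]c(-c4n[nH]c5ccccc45)cc3n2)c1` gives 1420 nM in this assay, and compound 3 `CN(C(=O)c1ccco1)c1ccc2[nH]c(-c3n[nH]c4ccccc34)cc2n1` gives 4540 nM in this assay. Compound 3 thus holds the second highest of the three numbers; its nearest neighbour is compound 1, with a 1.1-fold lower number from compound 1 to compound 3 (0.03 log units; within the scatter), and its furthest is compound 2, with a 3.2-fold higher number from compound 2 to compound 3 (0.50 log units; beyond the scatter). The remaining step, a 3.4-fold lower number from compound 1 to compound 2 (0.53 log units; beyond the scatter), is the only one beyond the scatter besides that.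

Compound 4 `CN(c1ccc2[nH]c(-c3n[nH]c4ccccc34)cc2n1)S(=O)(=O)c1ccc(Br)cc1` differs from compound 3 by (4-bromophenyl)sulfonyl in place of (furan-2-yl)carbonyl on a nitrogen on an aromatic ring. Going by the values given here, no measured step touches the carbonyl itself; the steps that bear on the change concern only the ring attached to it, where furan-2-yl for phenyl stayed within the scatter and the methoxy-bearing ring brought a modest gain. Compound 4 is therefore expected to show only a small step in this assay, a 1.5-fold lower number from compound 3 to compound 4 (0.18 log units; within the scatter), with wide uncertainty. Compound 4 is estimated at 3000 nM, between 900 nM and 10000 nM.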

Compound 4, half-maximal inhibitory concentration: 6240 nM
Beside the measured number, compound 4's estimate is 2.1-fold (0.32 log units) below it; the measured number falls inside the stated range.
By their numbers in this assay, from the lowest: compound 2; then compounds 3, 1 and 4 (each within the scatter of the next).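

Going by these compounds alone, putting a sulfonyl link on this nitrogen, the first change to the link itself, hardly moves the number in this assay (a 1.4-fold higher number from compound 3 to compound 4 (0.14 log units; within the scatter); a 1.3-fold higher number from compound 1 to compound 4 (0.11 log units; within the scatter)). The (4-bromophenyl)sulfonyl group therefore sits with benzoyl and (furan-2-yl)carbonyl, while compound 2, with its (3-methoxyphenyl)carbonyl group, remains the only one apart (a 4.4-fold higher number from compound 2 to compound 4 (0.64 log units; beyond the scatter)). No supporting data bear on why the sulfonyl link and the bromine-carrying ring together leave the number within the scatter.

The link and the ring change together in every new step, so the compounds shown do not separate the sulfonyl from the bromine. On these data alone, it remains open whether the 3-methoxy gain carries over to a (3-methoxyphenyl)sulfonyl group, and what an amine or a carboxylic acid on that ring would do.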